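Substitution at the core of compound 2 and its expected read-out

This account rests on a few compounds, and the source may have more. Where it says the series, first, only, none or still open, it means among the compounds named here.

Measured so far:
compound 1, `Nc1ncnc2c1nc(O)n2Cc1ccccc1` — 10 uM
compound 2, `CCCc1nc(N)c2nc(O)n(Cc3ccccc3)c2n1` — 1 uM

In a functional assay (spleen, spleen) for activation, with Mus musculus as the target (a lower number here means that less compound is needed, a higher number that more compound is needed for the effect), compound 2 holds the lowest of the two numbers; the nearest is compound 1, whose number is higher. Within the data shown here, the only step in hand, a 10-fold lower number from compound 1 to compound 2 (1.00 log units; beyond the scatter), joins the two.

Compound 3, `CSc1nc(N)c2nc(O)n(Cc3ccccc3)c2n1`, follows from compound 2 by one change, (methylsulfanyl in place of propyl on an aromatic carbon). Among the measured compounds shown here, the same position carries the one measured step, so that step bears on compound 3; it shows that putting a small group where compound 1 has hydrogen lowers the number by a modest amount. Compound 3 keeps a small group there, of different kind and shorter, so a step from compound 2 toward a somewhat higher number, or none beyond the scatter, is expected: a 2.0-fold higher number from compound 2 to compound 3 (0.30 log units; within the scatter). Compound 3 is therefore estimated at 2 uM in this assay, within 0.5 uM to 10 uM.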

Compound 3, minimum effective concentration: 0.1 uM
Compound 3: middle estimate off by 20-fold (1.30 log units), on the high side; the measured number lies below the stated range.
By their numbers in this assay, from the lowest: compound 3; then compound 2; then compound 1.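

In this assay, the change from propyl to methylsulfanyl on the aromatic carbon between two ring nitrogen atoms gives a 10-fold lower number from compound 2 to compound 3 (1.00 log units; beyond the scatter) and so shows that this position still responds after propyl has been introduced. Measured against hydrogen, methylsulfanyl gives a 100-fold lower number from compound 1 to compound 3 (2.00 log units; beyond the scatter) and thus exceeds the step seen with propyl, although it has 2 heavy atoms against the 3 of propyl, so across these three compounds the number does not simply fall as heavy atoms are added. Nothing available here explains why methylsulfanyl and propyl differ.

The compounds shown leave open whether the lower number goes with the sulfur atom or with the shorter chain. A methoxy group, an ethyl chain or an ethylsulfanyl group at this carbon would bear directly on that question.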